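The source may hold more compounds than are shown below. What is called first, only, known or untested is meant among the compounds shown, and "the series" means these compounds.

Compound 1 `N#Cc1ccc(Cn2cncc2CNc2ccc(C(=O)Nc3cccc([N+](=O)[O-])c3)c(-c3ccccc3)c2)cc1` was tested in a functional assay on NIH3T3 cells (Mus musculus); a lower number here means that less compound is needed, a higher number that more compound is needed for the effect. There compound 1 gives > 10 uM, which is a limit of the assay rather than a measured number. Two related compounds were run in the same test. Compound 2 `CSCC[C@H](NC(=O)c1ccc(NCc2cncn2Cc2ccc(C)cc2)cc1-c1ccccc1)C(=O)O` gives > 10 uM in this assay, again a limit. Compound 3 `COC(=O)[C@H](CCSC)NC(=O)c1ccc(NCc2cncn2Cc2ccccc2C)cc1-c1ccccc1` gives > 10 uM in this assay, once more a limit. All three shown values sit at the same place, as the limit of > 10 uM in this assay, at which 3 of the 3 values shown sit, records, so no step between measured compounds can be sized.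

Compound 4 `CSCNC(=O)c1ccc(NCc2cncn2Cc2ccc(C#N)cc2)cc1-c1ccccc1` has not yet been measured. It differs from compound 1 in one place: (methylsulfanyl)methyl in place of 3-nitrophenyl on an amide-type nitrogen, so a (methylsulfanyl)methyl group, rather than a 3-nitrophenyl group, stands on the amide-type nitrogen whose other neighbour is the carbonyl carbon. For the measured compounds named here, with compound 1 known only as a limit, the numbers do not fix the size or direction of the change; no measured pair shows what such a swap does. The step that the limit leaves unreadable from compound 1 to compound 4 is estimated as none beyond the scatter. Compound 4 is expected to give about 15 uM in this assay, within a range from 3 uM to 60 uM, with a real chance that only a limit is reported again.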

Compound 4, concentration for half-maximal effect: > 10 uM
Compound 4: only a limit was reported; the forecaster's own chance of this, stated with the estimate: 70%; the middle value does not contradict the limit.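

In this assay compound 4 gives > 10 uM, which is a limit. Compound 1 is also known only as a limit, so no step from compound 1 to compound 4 can be read: the limit of > 10 uM in this assay, at which 4 of the 4 values shown sit.

The compounds shown leave open how much of each is needed for the effect, and whether placing (methylsulfanyl)methyl in place of 3-nitrophenyl changes that amount at all.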